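Triazolopyrimidine series: amine variation at the shared core

The source may report more compounds than this note shows. Statements on the series, on what has been measured and on what is new or still open speak of the compounds shown alone.

Measured so far in an in vitro assay on 293-EBNA cells for binding affinity to corticotropin-releasing factor receptor 1 (Homo sapiens); on this read-out lower numbers stand for stronger inhibition and higher numbers for weaker inhibition:
compound 1, `Cc1nc(N2CCCCC2)c2nnn(-c3ccc(C(C)C)cc3Br)c2n1`, 46 nM
compound 2, `CCC(COC)N(C)c1nc(C)nc2c1nnn2-c1ccc(C(C)C)cc1Br`, 11.2 nM
compound 3, `COCCNc1nc(C)nc2c1nnn2-c1c(C)cc(C)cc1C`, 1200 nM

Compound 3 stands highest of the three numbers in this assay; compound 1 is its nearest neighbour and compound 2 is furthest from it, both gaps beyond the scatter.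

Compound 4, `CCCCC(CC)Nc1nc(C)nc2c1nnn2-c1c(C)cc(C)cc1C`, differs from compound 3 by 1-ethylpentyl in place of 2-methoxyethyl on a nitrogen on an aromatic ring. Among the compounds with values here, only one measured step exists, a 4.1-fold lower number from compound 1 to compound 2 (0.61 log units; beyond the scatter), and it changes a different amine at a different aryl substitution, so it bears on the present change only loosely: it shows that an acyclic branched amine can give a lower number than a cyclic one. Within the data shown here, a lower number is therefore expected for compound 4, a modest to sizeable step a 12-fold lower number from compound 3 to compound 4 (1.08 log units; beyond the scatter), with wide uncertainty since no closer precedent exists. Compound 4 is estimated at 100 nM, in the range 20 nM to 500 nM.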

Compound 4, inhibition constant: 7.6 nM
The estimate for compound 4 lay 13-fold (1.12 log units) above the measured number; measured number outside the range, below it.
By their numbers in this assay, from the lowest: compounds 4 and 2 (each within the scatter of the next); then compound 1; then compound 3.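

In this assay, this position on the shared core proves highly sensitive to the amine substituent: 1-ethylpentyl in place of 2-methoxyethyl on a nitrogen on an aromatic ring gives a 160-fold lower number from compound 3 to compound 4 (2.20 log units; beyond the scatter). Chain size and hydrogen-bond acceptor count change together here, with the oxygen of 2-methoxyethyl leaving, so this single step cannot separate the two. Nothing available explains the size of the step.

As far as these compounds go, whether a straight heptyl chain or a 1-ethylpropyl group on the same nitrogen would give a similar number remains open. Also open, from the compounds shown here alone, is whether 1-ethylpentyl gives a comparable number with the aryl group of compound 1.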